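A few compounds are considered here, and "the series" means these few. Any claim that something is new, unique, unknown or untested is made for them only; others in the source may bear on it.

The measured compounds:
compound 1 `CC(C)c1onc(-c2c(Cl)cccc2Cl)c1COc1ccc(-c2nc3ccc(C(=O)O)cc3n2C2CCCC2)cc1`, 929 nM
compound 2 `CCCn1c(-c2ccc(OCc3c(-c4c(Cl)cccc4Cl)noc3C(C)C)cc2)nc2ccc(C(=O)O)cc21`, 1400 nM
compound 3 `CC(C)c1onc(-c2c(Cl)cccc2Cl)c1COc1ccc(-c2nc3ccc(C(=O)O)cc3n2Cc2ccc(F)cc2)cc1`, 1140 nM

In an assay on HEK-293T cells for antagonist activity at vitamin D3 receptor (Homo sapiens), read by a luciferase reporter, with a stated time of 24 h (on this read-out lower numbers stand for stronger inhibition and higher numbers for weaker inhibition), compound 3 gives 1140 nM, the second highest of the three numbers; its nearest neighbour is compound 1 at 929 nM, its furthest compound 2 at 1400 nM. Compound 4 `CCCC(CCC)n1c(-c2ccc(OCc3c(-c4c(Cl)cccc4Cl)noc3C(C)C)cc2)nc2ccc(C(=O)O)cc21` differs from compound 3 in one place: 1-propylbutyl in place of 4-fluorobenzyl on an aromatic nitrogen. Among the compounds with values here, the steps that bear on this change are a 1.5-fold higher number from compound 1 to compound 2 (0.18 log units; within the scatter) and a 1.2-fold higher number from compound 1 to compound 3 (0.09 log units; within the scatter), both within the scatter, as is a 1.2-fold lower number from compound 2 to compound 3 (0.09 log units; within the scatter). Exchanging the group on the aromatic nitrogen among cyclopentyl, propyl and 4-fluorobenzyl has left this assay where it was, so no step beyond the scatter is expected for a 1.0-fold lower number from compound 3 to compound 4 (0.02 log units; within the scatter). Compound 4 is therefore estimated at 1100 nM, within 500 nM to 2500 nM.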

Compound 4, half-maximal inhibitory concentration: > 10000 nM
Compound 4: only a limit was reported (the forecaster's own chance of this, stated with the estimate: 5%); at least 9.0-fold (0.95 log units) between middle value and limit.
By their numbers in this assay, from the lowest: compounds 1, 3 and 2 (each within the scatter of the next). At a limit, above all of these: compound 4.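

In this assay compound 4 is reported only as a limit: the limit of > 10000 nM in this assay, at which 1 of the 4 values shown sits.
The steps of an at least 8.7-fold higher number from compound 3 to compound 4 (0.94 log units; beyond the scatter) and an at least 7.1-fold higher number from compound 2 to compound 4 (0.85 log units; beyond the scatter) and an at least 10-fold higher number from compound 1 to compound 4 (1.03 log units; beyond the scatter) all lie beyond the scatter, so this aromatic nitrogen does not accept every group alike, as the earlier exchanges had suggested. Having no ring does not sort the groups, since propyl also has none and compound 2 stays within the scatter of compounds 1 and 3.

Going by these compounds, what remains open is whether the change follows the branching of 1-propylbutyl or its length. A 1-ethylpropyl group or a straight hexyl chain on this nitrogen would separate the two.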